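Methoxy for Chloro on a Quinoxaline Dioxide Core

A few compounds are considered here, and "the series" means these few. Any claim that something is new, unique, unknown or untested is made for them only; others in the source may bear on it.

Measured so far:
compound 1 `COc1ccc2c(c1)[n+]([O-])c(C(=O)N=[N+]=[N-])c(C)[n+]2[O-]`: 99%
compound 2 `Cc1c(NC(=O)OC(C)C)[n+]([O-])c2cc(Cl)ccc2[n+]1[O-]`: 98.8%

In a functional assay on Ehrlich cells (Mus musculus) for cytotoxicity, read by trypan blue exclusion, with a stated time of 2 h, tested at 5 ug/mL (a higher number here means a weaker effect of the compound at the concentration tested, a lower number a stronger effect), compound 2 gives 98.8%, a value that sits within the scatter of what compound 1 shows, so the two cannot be told apart. Compound 3 `COc1ccc2c(c1)[n+]([O-])c(NC(=O)OC(C)C)c(C)[n+]2[O-]` differs from compound 2 in one place: methoxy in place of chloro on an aromatic carbon. Compound 1 already carries a methoxy at that same position and shows no stronger effect, so no step beyond the scatter is expected in this assay. For compound 3 the estimate is 99%, between 92% and 100%, meaning an expected step of a number 0.2 percentage points higher from compound 2 to compound 3 (within the scatter).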

Compound 3, a percentage reported as activity, at one concentration (the size of the read-out at that concentration, not a potency): 99%
Estimate against measurement, compound 3: no gap at the digits printed; the measured number falls inside the stated range.
By their numbers in this assay, from the lowest: compounds 2, 1 and 3 (each within the scatter of the next).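

In this assay, methoxy in place of chloro on an aromatic carbon gives a number 0.2 percentage points higher from compound 2 to compound 3 (within the scatter), so this direct comparison shows no measurable effect of the change at this position. Exchanging the group of 5 heavy atoms for the group of 7 heavy atoms on an aromatic carbon gives no change at the digits printed from compound 1 to compound 3 (within the scatter), so that change cannot be told apart from the scatter either. No available evidence bears on why the readings stay level. On these data alone, whether an amine or a carboxylic acid at the chloro position would shift the read-out remains open.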